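The source may report more compounds than this note shows. Statements on the series, on what has been measured and on what is new or still open speak of the compounds shown alone.

In an assay on U-87MG ATCC cells for inhibition of RAC-alpha serine/threonine-protein kinase (Homo sapiens), read by AlphaScreen, with a stated time of 2 h (a higher number here means a weaker inhibitor, a lower number a stronger inhibitor), compound 1 `Nc1nc2ccc(-c3cnc(Cl)c(NS(=O)(=O)c4ccc(F)cc4)c3)cc2s1` gives 44 nM. Compound 2 `O=S(=O)(Nc1cc(-c2ccc3nc[nH]c3c2)cnc1Cl)c1ccc(F)cc1` reaches only the limit of this assay, recorded as > 12000 nM. Of the two values shown, one sits at that limit (the limit of > 12000 nM in this assay, at which 1 of the 2 values shown sits). Compound 3 `O=S(=O)(Nc1cc(-c2ccc3nccn3c2)cnc1Cl)c1ccc(F)cc1` differs from compound 2 by a group of 9 heavy atoms (7 carbon, 2 nitrogen; one five-membered aromatic ring with 2 hetero atoms, one six-membered aromatic ring with 1 hetero atom) in place of a group of 9 heavy atoms (7 carbon, 2 nitrogen; one five-membered aromatic ring with 2 hetero atoms, one six-membered aromatic ring of carbon only), on an aromatic carbon. Within the data shown here, no measured step covers this change, and compound 2 itself gives no number to step from. The change is expected to move this assay by no more than the usual scatter, in either direction. Compound 3 is therefore expected at 9000 nM, between 2000 nM and 40000 nM, which means a step of an at least 1.3-fold lower number from compound 2 to compound 3 (0.12 log units; that floor lies within the scatter).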

Compound 3, half-maximal inhibitory concentration: 574 nM
The estimate for compound 3 lay 16-fold (1.20 log units) above the measured number; measured number outside the range, below it.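

Compound 2 sits at a limit of this assay, > 12000 nM, and not at a measured number. With the same atoms joined differently, exchanging the 1H-benzimidazol-6-yl group for the group of compound 3 on this aromatic carbon gives an at least 20-fold lower number from compound 2 to compound 3 (1.32 log units; beyond the scatter), so this position distinguishes between two groups of equal atom count. The size of the step is therefore only a bound: the limit of > 12000 nM in this assay, at which 1 of the 3 values shown sits.

The pair does not separate the loss of the hydrogen-bond donor from the added ring hetero atom. Going by these compounds, how a methoxy group or a carboxylic acid on the entering group would read remains open.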